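Ester side chain variation in a dihydropyridine series

The source may hold more compounds than are shown below. What is called first, only, known or untested is meant among the compounds shown, and "the series" means these compounds.

Measured compounds in a functional assay on HEK293 cells for antagonist activity at Voltage-dependent L-type calcium channel subunit alpha-1C (Oryctolagus cuniculus), read by FLIPR; on this read-out higher numbers stand for weaker inhibition and lower numbers for stronger inhibition:
- compound 1, `COC(=O)C1=C(C)NC(C)=C(C(=O)OCCCl)C1c1cccc([N+](=O)[O-])c1`, gives 26 nM
- compound 2, `COC(=O)C1=C(C)NC(C)=C(C(=O)OCC(C)[N+](=O)[O-])C1c1cccc([N+](=O)[O-])c1`, gives 108 nM
- compound 3, `COC(=O)C1=C(C)NC(C)=C(C(=O)OCc2ccccc2)C1c1cccc([N+](=O)[O-])c1`, gives 25 nM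

Compound 3 gives the lowest number of the three, but its step to compound 1 is within the scatter: a 1.0-fold lower number from compound 1 to compound 3 (0.02 log units; within the scatter). Only compound 2 stands clearly apart, with a 4.3-fold lower number from compound 2 to compound 3 (0.64 log units; beyond the scatter) and a 4.2-fold higher number from compound 1 to compound 2 (0.62 log units; beyond the scatter). So far every change sits on the saturated chain carbon bound to an oxygen next to a carbonyl group, and exchanging chloromethyl for phenyl there left the number unchanged.

Compound 4, `COC(=O)C1=C(C)NC(C)=C(C(=O)OCc2ccc(OC)cc2)C1c1cccc([N+](=O)[O-])c1`, is obtained from compound 3 by methoxy in place of hydrogen on an aromatic carbon. For the measured compounds named here, no measured step touches the aromatic ring itself, so the expectation rests on the observation that only the 1-nitroethyl side chain of compound 2 moved the number beyond the scatter, while chloromethyl and phenyl gave the same result. A step of a 1.2-fold higher number from compound 3 to compound 4 (0.08 log units; within the scatter) is therefore expected, with no change beyond the scatter as the most likely outcome. Compound 4 is estimated at 30 nM, within 10 nM to 90 nM.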

Compound 4, half-maximal inhibitory concentration: 51 nM
Compound 4: middle estimate off by 1.7-fold (0.23 log units), on the low side; low and high end bracket the measured number.
By their numbers in this assay, from the lowest: compounds 3, 1 and 4 (each within the scatter of the next, the first and the last beyond it); then compound 2.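

Methoxy in place of hydrogen on the aromatic carbon para to a large group gives a 2.0-fold higher number from compound 3 to compound 4 (0.31 log units; beyond the scatter) in this assay, so the aromatic ring of the benzyl ester is not silent, although the step is modest. Compared with the other side chains, the result is split: a 2.1-fold lower number from compound 2 to compound 4 (0.33 log units; beyond the scatter) lies beyond the scatter, while a 2.0-fold higher number from compound 1 to compound 4 (0.29 log units; within the scatter) lies within it, so the 4-methoxybenzyl ester cannot be told apart from the chloroethyl ester of compound 1 on this read-out. No measurement at hand accounts for the methoxy step.

Open, going by these compounds, is whether a hydroxyl, a chlorine or an amine at the same ring place shifts the number as methoxy does. Also open, on these data alone, is whether a longer chain between the ester oxygen and the phenyl ring changes the number at all.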